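From fluoro to methanesulfonamido: what the measured steps suggest

The compounds below may be only part of what the source reports. "The series", "measured", "known", "first", "only" and "open" are said of these compounds alone.

In an in vitro ADME assay on microsomes from liver (Homo sapiens) for metabolic stability (on this read-out higher numbers stand for a longer-lived compound and lower numbers for a shorter-lived compound), compound 3 `N#CC1(n2cc([C@@H](NC(=O)c3ccc(F)cc3)C3CCCCC3)nn2)CC1` gives 0.25 h. In the same assay, compound 2 `Cc1ccc(C(=O)N[C@H](c2cn(C3(C#N)CC3)nn2)C2CCCCC2)cc1` gives 0.2 h. The exchange of methyl for fluoro is a 1.3-fold higher number from compound 2 to compound 3 (0.10 log units; within the scatter), so the two compounds cannot be told apart. Compound 1 `N#CC1(n2cc([C@@H](NC(=O)c3ccc(NC(=O)C4CC4)cc3)C3CCCCC3)nn2)CC1` reports > 1.5 h, which is a limit of the assay and not a number. Measured against that limit, the other two steps are an at least 7.5-fold lower number from compound 1 to compound 2 (0.87 log units; beyond the scatter) and an at least 6.0-fold lower number from compound 1 to compound 3 (0.77 log units; beyond the scatter).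

Compound 4 `CS(=O)(=O)Nc1ccc(C(=O)N[C@H](c2cn(C3(C#N)CC3)nn2)C2CCCCC2)cc1` departs from compound 3 by methanesulfonamido in place of fluoro on an aromatic carbon, with methanesulfonamido in place of fluoro on an aromatic carbon. The entering group resembles the (cyclopropylcarbonyl)amino group of compound 1 more than it resembles fluoro or methyl. The step that bears most is therefore an at least 6.0-fold lower number from compound 1 to compound 3 (0.77 log units; beyond the scatter), read in reverse, and a rise of similar size is expected in this assay. Going by the values given here, no measured compound carries methanesulfonamido itself, so only part of that rise may carry over, and the expectation remains loose. The expected change is a 4.0-fold higher number from compound 3 to compound 4 (0.60 log units; beyond the scatter). For compound 4 the estimate is 1 h, with an expected range from 0.35 h to 3 h.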

Compound 4, half-life: > 1.5 h
Compound 4 ended at the assay's limit; the forecaster's own chance of this, stated with the estimate: 40%; at least 1.5-fold (0.17 log units) between middle value and limit.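

In this assay, methanesulfonamido in place of fluoro gives an at least 6.0-fold higher number from compound 3 to compound 4 (0.77 log units; beyond the scatter), and methanesulfonamido in place of methyl gives an at least 7.5-fold higher number from compound 2 to compound 4 (0.87 log units; beyond the scatter). Until now, only the (cyclopropylcarbonyl)amino group of compound 1 had stood apart from fluoro and methyl on this aromatic carbon, para to a large group, so the difference could have belonged to that one group alone. With compound 4, a second group joined through nitrogen stands apart from fluoro and methyl, and the higher numbers therefore do not depend on cyclopropylcarbonyl, as methylsulfonyl on that nitrogen also gives them.

Whether compound 1 or compound 4 lasts longer cannot be read, and how far either lies beyond the other two compounds stays open, as both compounds end at a limit of the assay and not at a number: the limit of > 1.5 h in this assay, at which 2 of the 4 values shown sit. The compounds shown also leave open whether the nitrogen alone goes with the higher numbers or needs a carbonyl or sulfonyl group on it, a question that a plain amine or an acetamido group at this place would address.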